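Cinnamamide series on a shared anilinoquinazoline core: compound 4

This account rests on a few compounds, and the source may have more. Where it says the series, first, only, none or still open, it means among the compounds named here.

Working notes on a small set of cinnamamide derivatives that share the core shown in compound 1 `COc1cc(/C=C/C(=O)Nc2cc3c(Nc4ccc(F)c(Cl)c4)ncnc3cc2O[C@H]2CCOC2)cc(OC)c1O`. In a functional assay on MCF7 cells (Homo sapiens) for cytotoxicity, read by MTT assay, with a stated time of 72 h (a lower number here means a stronger inhibitor, a higher number a weaker inhibitor), compound 1 gives 30500 nM, the lowest of the two numbers recorded so far. Compound 2 `COc1cc(/C=C/C(=O)Nc2cc3c(Nc4ccc(F)c(Cl)c4)ncnc3cc2OC)cc(OC)c1` is the closest in value: in this assay compound 2 gives 38500 nM, and the gap between compound 1 and compound 2 lies within the scatter, so the two cannot be ordered. Compound 3 `COc1cc2ncnc(Nc3ccc(F)c(Cl)c3)c2cc1NC(=O)/C=C/c1ccc(C#N)cc1` carries a different aryl group on the cinnamamide and in this assay compound 3 is recorded as "not active" (no number reported), with no number attached.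

Compound 4 `COc1ccc(/C=C/C(=O)Nc2cc3c(Nc4ccc(F)c(Cl)c4)ncnc3cc2O[C@H]2CCOC2)c(OC)c1` is not yet measured. It differs from compound 1 in one place: 2,4-dimethoxyphenyl in place of 4-hydroxy-3,5-dimethoxyphenyl on a double-bonded chain carbon bound to a double-bonded chain carbon. Going by the values given here, no step between measured compounds isolates this change, so nothing recorded here sizes it. All numbers in the set are weak, and the aryl change in compound 3 gave "not active" (no number reported), so the expectation for the step from compound 1 to compound 4 is a modest move toward a higher number, possibly no more than the scatter, a 1.5-fold higher number from compound 1 to compound 4 (0.17 log units; within the scatter). For compound 4 in this assay the estimate is 45000 nM, with a range from 15000 nM to 130000 nM.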

Compound 4, half-maximal inhibitory concentration: 28600 nM
Beside the measured number, compound 4's estimate is 1.6-fold (0.20 log units) above it, and the stated range covers the measured number.
By their numbers in this assay, from the lowest: compounds 4, 1 and 2 (each within the scatter of the next).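

In this assay the exchange of 4-hydroxy-3,5-dimethoxyphenyl for 2,4-dimethoxyphenyl, on a double-bonded chain carbon bound to a double-bonded chain carbon, gives a 1.1-fold lower number from compound 1 to compound 4 (0.03 log units; within the scatter) and so produces no readable change at this position. Going by these compounds alone, this is the first step in the set that isolates a change at this position, and it shows that, with the rest of the structure held constant, losing the hydroxy group and rearranging the methoxy groups leaves the number in the same weak range for compound 1 and compound 4. Nothing at hand explains why the exchange leaves the number where it is.

As far as these compounds go, both members of this pair carry methoxy-substituted phenyl groups, so it remains open whether any group at this position can move the number beyond the scatter, for instance a phenyl ring bearing an amine or a carboxylic acid. A single step also leaves open whether the same exchange would read the same with a longer alkoxy chain in place of the ether group on the shared core.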